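The source may report more compounds than this note shows. Statements on the series, on what has been measured and on what is new or still open speak of the compounds shown alone.

Among the compounds with values here, in a functional assay on A549 cells (Homo sapiens) for inhibition, read by CCK-8 assay, with a stated time of 72 h, tested at 1 uM (a higher number here means more inhibition of growth at the concentration tested, a lower number less inhibition of growth), compound 2 `CN(C)C(=O)c1cc2cnc(Nc3ccc(NC(=O)C4(C(=O)Nc5ccc(Cl)c(C(F)(F)F)c5)CC4)cc3)nc2n1C1CCCC1` gives 1.1%, the lower of the two numbers so far, while compound 1 `Cc1cccc(NC(=O)C2(C(=O)Nc3ccc(Nc4ncc5cc(C(=O)N(C)C)n(C6CCCC6)c5n4)cc3)CC2)c1` gives 35.2%. Compound 3 `COc1cccc(NC(=O)C2(C(=O)Nc3ccc(Nc4ncc5cc(C(=O)N(C)C)n(C6CCCC6)c5n4)cc3)CC2)c1` has not been measured. It differs from compound 2 as follows: 3-methoxyphenyl in place of 4-chloro-3-(trifluoromethyl)phenyl on an amide-type nitrogen. Within the data shown here, only one measured step bears on this change, a number 34.1 percentage points lower from compound 1 to compound 2 (beyond the scatter), which is large and put the group now leaving in place of 3-methylphenyl on the same kind of nitrogen. Removing that group is expected to reverse much of this drop in this assay, so the expected step is large and upward: a number 28.9 percentage points higher from compound 2 to compound 3 (beyond the scatter). The estimated value for compound 3 is 30%, within a range of 12% to 52%.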

Compound 3, percent growth inhibition at one concentration: 77.2%
Compound 3: the middle estimate sits 47.2 percentage points below what was measured, and the stated range ends below it.
By their numbers in this assay, from the lowest: compound 2; then compound 1; then compound 3.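

In this assay, the group on this amide-type nitrogen sets the result over a wider span than the earlier pair showed: the change gives a number 76.1 percentage points higher from compound 2 to compound 3 (beyond the scatter). Even the smaller change of methoxy in place of methyl on an aromatic carbon gives a number 42 percentage points higher from compound 1 to compound 3 (beyond the scatter). Nothing measured here explains these differences.

Still open, going by these compounds, is whether a hydroxyl, an ethoxy or a dimethylamino group on that carbon would match methoxy. Also open, on these data alone, is whether chlorine alone or trifluoromethyl alone would bring the number down as far as in compound 2.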